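Swapping chloro for bromo on a weak monoamine oxidase A inhibitor

The compounds below may be only part of what the source reports. "The series", "measured", "known", "first", "only" and "open" are said of these compounds alone.

Measured compounds:
- compound 1 `COc1cccc(OCc2nc3c(c(=O)n(C)c(=O)n3C)n2C)c1`: "not active" (no number reported)
- compound 2 `Cn1c(=O)c2c(nc(CCSc3ccc(Cl)cc3)n2C)n(C)c1=O`: 142000 nM
- compound 3 `Cc1cccc(OCc2nc3c(c(=O)n(C)c(=O)n3C)n2C)c1`: 18800 nM

Three compounds share a core and were tested in an in vitro assay on cells for inhibition of Amine oxidase [flavin-containing] A (Homo sapiens), read by coupled enzyme assay, with a stated time of 20 min; a higher number here means a weaker inhibitor, a lower number a stronger inhibitor. Compound 1 gives "not active" (no number reported) there. Of the two compounds with a number, compound 2 has the higher value, so it is the weaker inhibitor; compound 3 sits lower, beyond the scatter. Compound 4 `Cn1c(=O)c2c(nc(CCSc3ccc(Br)cc3)n2C)n(C)c1=O` has not yet been measured. It differs from compound 2 by bromo in place of chloro on an aromatic carbon — bromo in place of chloro on an aromatic carbon. Among the measured compounds shown here, no step between measured compounds shows this change, so the expectation rests on compound 2 alone, with no direction, and the step from compound 2 to compound 4 is expected to be a 1.2-fold lower number from compound 2 to compound 4 (0.07 log units; within the scatter). Compound 4 is thus estimated at 120000 nM, within 40000 nM to 400000 nM.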

Compound 4, half-maximal inhibitory concentration: 117000 nM
For compound 4 the middle estimate is 1.0-fold (0.01 log units) above the measured one, and the stated range covers the measured number.
By their numbers in this assay, from the lowest: compound 3; then compounds 4 and 2 (each within the scatter of the next).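

In this assay, the swap of chloro for bromo gives a 1.2-fold lower number from compound 2 to compound 4 (0.08 log units; within the scatter) and this step lies within the scatter. The earlier compounds shown here offered no pair differing at this position, and here 4-chlorophenyl and 4-bromophenyl cannot be told apart. No measurement shown here bears on the reason for this result. Still open, as far as these compounds go, is whether an amine or a carboxylic acid at this position would shift the number beyond the scatter. Also open, from the compounds shown here alone, is whether the same swap would behave alike on the side chain of compound 3.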